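Moving a nitro group from one ring position to another

The compounds below may be only part of what the source reports. "The series", "measured", "known", "first", "only" and "open" are said of these compounds alone.

Compound 1, `COc1cc(/C=C2\CCC/C(=C\c3cccc([N+](=O)[O-])c3)C2=O)cc(OC)c1OC`, gives 45200 nM in a functional assay on CCRF-CEM cells (Homo sapiens) for cytotoxicity, with a stated time of 72 h; on this read-out lower numbers stand for stronger inhibition and higher numbers for weaker inhibition.
Compound 3, `CN(C)c1ccc(/C=C2\CCC/C(=C\c3cccc([N+](=O)[O-])c3)C2=O)cc1`, gives 11700 nM in this assay.
Compound 2, `CN(C)c1ccc(/C=C2\CCC/C(=C\c3ccc([N+](=O)[O-])cc3)C2=O)cc1`, reaches only a limit of this assay, > 500000 nM, and no number.

Of the two compounds with a number, compound 1 stands higher than compound 3, a gap beyond the usual scatter. The difference between the core of compound 1 and the core of compound 3 is not broken down here.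

Compounds 3 and 2 share a core and differ in one place: 4-nitrophenyl in place of 3-nitrophenyl on a double-bonded chain carbon bound to a double-bonded ring carbon. This change made a large step, an at least 42-fold higher number from compound 3 to compound 2 (1.63 log units; beyond the scatter). Its true size is open upward, since (the limit of > 500000 nM in this assay, at which 1 of the 3 values shown sits).

The unmeasured compound 4, `COc1cc(/C=C2\CCC/C(=C\c3ccc([N+](=O)[O-])cc3)C2=O)cc(OC)c1OC`, is related to compound 1 by the same change, at the same place: 4-nitrophenyl in place of 3-nitrophenyl on a double-bonded chain carbon bound to a double-bonded ring carbon. Because the earlier step of an at least 42-fold higher number from compound 3 to compound 2 (1.63 log units; beyond the scatter) was large and compound 1 already starts at the higher number 45200 nM, compound 4 is expected to lose further, with an estimated step of an 18-fold higher number from compound 1 to compound 4 (1.25 log units; beyond the scatter). It is expected that compound 4 will most likely also sit beyond the reach of this assay, with an estimated value of 800000 nM, between 150000 nM and 4000000 nM; this rests on two compounds only, so the expectation is loose.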

Compound 4, half-maximal inhibitory concentration in the CCRF-CEM assay: 4610 nM
For compound 4 the middle estimate is 170-fold (2.24 log units) above the measured one, outside the stated range (below it).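

In the CCRF-CEM assay compound 4 gives 4610 nM, and 4-nitrophenyl in place of 3-nitrophenyl gives a 9.8-fold lower number from compound 1 to compound 4 (0.99 log units; beyond the scatter), so on this core the change goes with stronger inhibition, whereas on the core of compound 3 it goes with weaker inhibition, and the two steps clearly differ: the same change on two cores in the CCRF-CEM assay, an at least 42-fold higher number (1.63 log units; beyond the scatter) from compound 3 to compound 2 and a 9.8-fold lower number (0.99 log units; beyond the scatter) from compound 1 to compound 4, at least 410-fold (2.62 log units) apart, beyond the scatter of two such steps

In the CCRF-CEM assay, compound 2 gives > 500000 nM, which is a limit of the assay and not a number.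

Among these compounds, the result shows that the size and even the direction of this change cannot be carried from one core to the other, but it rests on only two pairs and does not show why the direction reverses, and in a physicochemical assay for lipophilicity (on this read-out lower numbers stand for lower lipophilicity and higher numbers for higher lipophilicity), this pair gives a number 0.02 log units higher from compound 1 to compound 4 (within the scatter). In the physicochemical assay compound 1 gives 5.06 and compound 4 gives 5.08.

The compounds shown leave open how the same change behaves on other cores, for example one with a morpholine or a carboxylic acid where compound 3 has its dimethylamino group. They also leave open whether a group other than nitro, such as a nitrile, would show the same reversal between the core of compound 1 and the core of compound 3.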